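Single ester of compound 3 against the double ester

This account rests on a few compounds, and the source may have more. Where it says the series, first, only, none or still open, it means among the compounds named here.

Measured so far:
- compound 1, `C[C@@H](O)[C@H]1C(=O)N2C(C(=O)OCOC(=O)C(C)(C)C)=C(S[C@@H]3CN[C@H](C(=O)Nc4cccc(C(=O)OCOC(=O)C(C)(C)C)c4)C3)[C@H](C)[C@H]12`, in an ADME assay on a cell-free system (plasma, Homo sapiens) for metabolic stability, read by LC-MS, with a stated time of 60 min, at 37 degrees C, tested at 50 uM (a higher number here means that more of the compound is left, a lower number that less of the compound is left), compound 1 gives 36%
- compound 2, `CCOC(=O)c1cccc(NC(=O)[C@@H]2C[C@H](SC3=C(C(=O)O)N4C(=O)[C@H]([C@@H](C)O)[C@H]4[C@H]3C)CN2)c1`, in this assay compound 2 gives "not determined" (no result reported)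

Compound 2 stands nowhere on the numbers: for compound 2 this assay returned "not determined" (no result reported), so there is no figure to set beside compound 1. Going by the values given here, the only number is that of compound 1, which in this assay gives 36%.

Compound 3, `C[C@@H](O)[C@H]1C(=O)N2C(C(=O)O)=C(S[C@@H]3CN[C@H](C(=O)Nc4cccc(C(=O)OCOC(=O)C(C)(C)C)c4)C3)[C@H](C)[C@H]12`, is the next entry for this assay. It differs from compound 2 in one place: ((tert-butyl)carbonyl)oxy in place of methyl on a saturated chain carbon bound to an oxygen next to a carbonyl group. The change sits on a saturated chain carbon bound to an oxygen next to a carbonyl group.

Among the compounds with values here, no step between measured compounds is recorded, so the size and direction of the move from compound 2 to compound 3 in this assay cannot be read from the data; with compound 2 unmeasured, the expectation rests on the single figure of compound 1 alone. A moderate remaining fraction is expected, with a wide range to cover the uncertainty.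

Compound 3 is expected to give about 45%, estimated between 20% and 75%.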

Compound 3, percent of the compound remaining: 53%
For compound 3 the middle estimate is 8 percentage points below the measured one; the range from low to high includes it.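

In this assay, going by these compounds alone, hydrogen in place of (((tert-butyl)carbonyl)oxy)methyl on an oxygen next to a carbonyl group gives a number 17 percentage points higher from compound 1 to compound 3 (beyond the scatter), the first change whose size and direction can be read. The ((((tert-butyl)carbonyl)oxy)methoxy)carbonyl group is present in both compounds, so the step belongs to this one oxygen alone, and it shows that the number at this position responds to the change. Even so, compound 3 gives 53%, so a free hydrogen on that oxygen leaves a substantial part of the compound gone at the end of the incubation, and nothing measured accounts for the step.

The step between compound 2 and compound 3 cannot be read, since compound 2 has no number, and the comparison of ethoxycarbonyl with ((((tert-butyl)carbonyl)oxy)methoxy)carbonyl therefore stays unresolved. Also open, from the compounds shown here alone, is how a simple ethyl on the oxygen next to a carbonyl group, or a primary amide in place of the ethoxycarbonyl group, would stand in this assay.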